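Adding a Fluoro Group to Compound 3: Expected Cytotoxicity

The source may hold more compounds than are shown below. What is called first, only, known or untested is meant among the compounds shown, and "the series" means these compounds.

Compound 1 `O=C(Nc1ccc(Oc2ccnc3[nH]ccc23)cc1)c1nn(-c2ccc(Cl)cc2)ccc1=O` gives in a functional assay on MCF7 cells (Homo sapiens) for cytotoxicity, read by MTT assay, with a stated time of 72 h (a higher number here means a weaker inhibitor, a lower number a stronger inhibitor), a value of 10600 nM.
Compound 2 `COc1ccc(-n2ccc(=O)c(C(=O)Nc3ccc(Oc4ccnc5[nH]ccc45)c(F)c3)n2)cc1` gives in this assay a value of 55400 nM.
Compound 3 `Cn1ccc2c(Oc3ccc(NC(=O)c4nn(-c5ccc(Cl)cc5)ccc4=O)cc3)ccnc21` gives in this assay only a limit, > 60000 nM.

Compound 3 therefore sits at the edge of what this measurement can report: its value is a limit, not a number, and the limit of > 60000 nM in this assay, at which 1 of the 3 values shown sits, marks that edge. For the measured compounds named here, the only single change measured so far, an at least 5.6-fold higher number from compound 1 to compound 3 (0.75 log units; beyond the scatter), is the one that carries compound 1 to compound 3 and moves the reading up to that limit.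

Compound 4 `Cn1ccc2c(Oc3ccc(NC(=O)c4nn(-c5ccc(Cl)c(F)c5)ccc4=O)cc3)ccnc21` differs from compound 3 by a single small change: fluoro in place of hydrogen on an aromatic carbon. Going by the values given here, no measured pair differs in that place, so nothing measured bears directly on this change. Among the compounds with values here, compound 2 carries a fluoro group on a different ring and a methoxy group in place of chloro, and is weaker than compound 1, but it differs in two places and gives no single step.

Within the data shown here, with the starting point already at a limit and no step of known size to draw on, compound 4 is expected to remain at or beyond that limit, the estimated step being a step that the limit leaves unreadable from compound 3 to compound 4. For compound 4 the expected value in this assay is 80000 nM, within a range from 30000 nM to 250000 nM.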

Compound 4, half-maximal inhibitory concentration: 16800 nM
For compound 4 the middle estimate is 4.8-fold (0.68 log units) above the measured one; the measured number lies below the stated range.
By their numbers in this assay, from the lowest: compounds 1 and 4 (each within the scatter of the next); then compound 2. At a limit, above all of these: compound 3.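

Changing 4-chlorophenyl to 4-chloro-3-fluorophenyl in this assay gives an at least 3.5-fold lower number from compound 3 to compound 4 (0.55 log units; beyond the scatter). Before this pair, the only single change measured was at the aromatic nitrogen of the core, so this is the first sign that the reading also responds to a single added atom on the 4-chlorophenyl group, at the carbon ortho to the chloro group. On these data alone, the size of this step is only a minimum, and its true size stays unknown, because compound 3 carries a limit and not a number: the limit of > 60000 nM in this assay, at which 1 of the 4 values shown sits.

As far as these compounds go, it remains open whether this drop belongs to fluoro itself or would also follow from another small group at the same carbon, such as a nitrile or an amine. From the compounds shown here alone, it is also open whether the same fluoro would give a step of similar size on compound 1, which keeps the hydrogen on its aromatic nitrogen, and whether such a step would hold in any setting other than this assay.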